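Drawing One Stereocentre: A Cytotoxicity Question

The source may report more compounds than this note shows. Statements on the series, on what has been measured and on what is new or still open speak of the compounds shown alone.

Measured in an ADME assay on MT4 cells (Homo sapiens) for cytotoxicity, read by MTT assay, with a stated time of 5 days (on this read-out higher numbers stand for lower toxicity in this test and lower numbers for higher toxicity in this test), so far:
- Compound 1 (`COc1cc(-c2ccc(C#N)cc2)ccc1[C@@H](O)c1ccnc(Nc2ccc(C#N)cc2)n1`) gives 33100 nM
- Compound 2 (`N#Cc1ccc(Nc2nccc([C@H](O)c3ccc(-c4ccc(C#N)cc4)cc3Cl)n2)cc1`) gives 28100 nM
- Compound 3 (`N#Cc1ccc(Nc2nccc(C(O)c3ccc(-c4ccc(C#N)cc4)cc3F)n2)cc1`) gives 14300 nM

Compound 3 (14300 nM) has a lower number than compound 1, a gap beyond the scatter, but lies within the scatter of compound 2.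

Compound 4 (`N#Cc1ccc(Nc2nccc([C@H](O)c3ccc(-c4ccc(C#N)cc4)cc3F)n2)cc1`) keeps every atom and bond of compound 3 (the two compounds have the same atoms and bonds; at least one stereo element is drawn with a configuration in one of them and without one in the other: 1 of 1 stereo elements differ; a stereocentre at a saturated chain carbon is drawn without a configuration in compound 3 and R in compound 4): a stereocentre at a saturated chain carbon is drawn without a configuration in compound 3 and R in compound 4.

Going by the values given here, the one measured step (a 1.2-fold lower number from compound 1 to compound 2 (0.07 log units; within the scatter)) puts chloro in place of methoxy on an aromatic carbon, stays within the scatter and does not test a configuration. In this assay the expected change is small and within the scatter (a 1.2-fold higher number from compound 3 to compound 4 (0.08 log units; within the scatter)). Compound 4 is estimated at 17000 nM (range 9000 nM to 33000 nM).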

Compound 4, half-maximal cytotoxic concentration: 30000 nM
The estimate for compound 4 lay 1.8-fold (0.25 log units) below the measured number; the measured number falls inside the stated range.
By their numbers in this assay, from the lowest: compounds 3, 2, 4 and 1 (each within the scatter of the next, the first and the last beyond it).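

In this assay, the step of a 2.1-fold higher number from compound 3 to compound 4 (0.32 log units; beyond the scatter) is the first one here beyond the scatter with no atom or bond changed, and the whole difference lies at one stereocentre: the fact that one of compounds 3 and 4 is drawn with a defined configuration and the other without, at the place where they differ

With a configuration drawn at that carbon, the aromatic group makes no readable difference: a 1.1-fold higher number from compound 2 to compound 4 (0.03 log units; within the scatter) and a 1.1-fold lower number from compound 1 to compound 4 (0.04 log units; within the scatter) both stay within the scatter.

The compounds shown leave open how the opposite configuration at this stereocentre would read. They also leave open whether an amine on that aromatic carbon would stay level with fluoro, chloro and methoxy.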